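The source may report more compounds than this note shows. Statements on the series, on what has been measured and on what is new or still open speak of the compounds shown alone.

Compound 3 `CC(C)(O)c1cn(Cc2nnc(-c3cc(S(N)(=O)=O)c(SCc4ccccc4)cc3Cl)o2)nn1` gives 0.23 h in an ADME assay on microsomes from liver (Homo sapiens) for metabolic stability, read by LC-MS, using NADPH, tested at 5 uM; on this read-out lower numbers stand for a shorter-lived compound and higher numbers for a longer-lived compound. Compound 1 `NS(=O)(=O)c1cc(-c2nnc(CN3CCN(c4ccccc4)CC3)o2)c(Cl)cc1SCc1ccccc1` gives 0.33 h, and compound 2 `NC(=O)c1cn(Cc2nnc(-c3cc(S(N)(=O)=O)c(SCc4ccccc4)cc3Cl)o2)nn1` gives 0.435 h. The steps of a 1.4-fold lower number from compound 1 to compound 3 (0.16 log units; within the scatter) and a 1.9-fold lower number from compound 2 to compound 3 (0.28 log units; within the scatter) both fall within the scatter, so compound 3 is not set apart from either of the other two. Compound 4 `COc1ccc(-c2cn(Cc3nnc(-c4cc(S(N)(=O)=O)c(SCc5ccccc5)cc4Cl)o3)nn2)cc1` differs from compound 3 by 4-methoxyphenyl in place of 1-hydroxy-1-methylethyl on an aromatic carbon. For the measured compounds named here, the one measured step at the same aromatic carbon, a 1.9-fold lower number from compound 2 to compound 3 (0.28 log units; within the scatter), stays within the scatter, as do a 1.3-fold higher number from compound 1 to compound 2 (0.12 log units; within the scatter) and a 1.4-fold lower number from compound 1 to compound 3 (0.16 log units; within the scatter), where the whole group on the saturated chain carbon was exchanged. Going by the values given here, no measured step therefore points to a shift beyond the scatter in this assay for this change. Compound 4 is expected to give 0.3 h, between 0.12 h and 0.75 h. The expected step is a 1.3-fold higher number from compound 3 to compound 4 (0.12 log units; within the scatter).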

Compound 4, half-life: 0.215 h
Estimate against measurement, compound 4: 1.4-fold (0.14 log units) above; measured number inside the range.
By their numbers in this assay, from the lowest: compounds 4, 3, 1 and 2 (each within the scatter of the next, the first and the last beyond it).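

At the aromatic carbon of the five-membered ring, 4-methoxyphenyl and 1-hydroxy-1-methylethyl cannot be told apart in this assay (a 1.1-fold lower number from compound 3 to compound 4 (0.03 log units; within the scatter)), although the entering group adds a six-membered aromatic ring and carries no hydrogen-bond donor. Against carbamoyl, the same group gives the only step beyond the scatter at this position (a 2.0-fold lower number from compound 2 to compound 4 (0.31 log units; beyond the scatter)), a modest one, while compound 3 stays within the scatter of both neighbours. Nothing available explains these values. Open, as far as these compounds go, is whether an amine or a carboxylic acid at this carbon would give a larger shift in half-life.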